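The source may report more compounds than this note shows. Statements on the series, on what has been measured and on what is new or still open speak of the compounds shown alone.

Compound 3 `O=C1c2cc(O)ccc2O[C@H](c2cccc(O)c2O)[C@H]1O` was tested in a functional assay on RAW264.7 cells (Rattus norvegicus) for inhibition, with RAW264.7 (Mus musculus) as the target, read by Griess assay, with stated times of 2 h and 16 h; a higher number here means a weaker inhibitor, a lower number a stronger inhibitor. In this assay compound 3 gives > 100000 nM, which is a limit of the assay rather than a number. Two other compounds stand beside it. Compound 1 `O=C1c2ccccc2O[C@@H](c2cccc(O)c2O)[C@@H]1O` gives in this assay > 100000 nM, again a limit. Compound 2 `O=C1c2ccccc2O[C@H](c2cccc(O)c2O)[C@H]1O` gives in this assay > 100000 nM, also a limit. Compound 2 is the mirror image of compound 1, and compound 3 adds a hydroxy to compound 2. The step that the two limits leave unreadable from compound 1 to compound 2 and the step that the two limits leave unreadable from compound 2 to compound 3 carry no readable size because of the limit of > 100000 nM in this assay, at which 3 of the 3 values shown sit. Compound 4 `O=C1c2cc(O)ccc2O[C@@H](c2cccc(O)c2O)[C@@H]1O` is the unmeasured partner of compound 3; the change is the two compounds have the same atoms and bonds and differ only in configuration as drawn: 2 of 2 stereo elements differ (all stereocentres are inverted: mirror images); a stereocentre at a saturated ring carbon is drawn R in compound 3 and S in compound 4; a stereocentre at a saturated ring carbon is drawn R in compound 3 and S in compound 4. This matches the relation between compound 1 and compound 2, as the fact that compounds 1 and 2 differ only in the configuration as drawn shows, and there the outcome in this assay stayed unreadable. The step that the limit leaves unreadable from compound 3 to compound 4 is thus expected to stay within the scatter. Compound 4 is expected to give about 150000 nM in this assay, with a range from 50000 nM to 1000000 nM, most likely reported again only as a limit.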

Compound 4, half-maximal inhibitory concentration: > 100000 nM
Compound 4: no number, only a limit; the forecaster's own chance of this, stated with the estimate: 85%; the middle value lies beyond the limit too.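

In this assay compound 4 gives > 100000 nM, which is a limit and not a number. No size can be read for the steps joining compound 4 to compound 3 and to compound 1. The compounds shown leave open whether configuration or the added hydroxy changes inhibition in this assay at all.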